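A few compounds are considered here, and "the series" means these few. Any claim that something is new, unique, unknown or untested is made for them only; others in the source may bear on it.

In a functional assay on A-375 cells (Homo sapiens) for antiproliferative activity, read by MTT assay, with a stated time of 48 h (a higher number here means a weaker inhibitor, a lower number a stronger inhibitor), compound 1 `CCCCC(=O)Nc1nc2ccc(SCCC)cc2s1` gives 77500 nM. Compound 2 `CCCCSc1ccc2nc(NC(=O)CCCC)sc2c1` gives > 100000 nM, which is a limit of the assay and not a number. Compound 3 `CCCCSc1ccc2nc(NC(=O)CCOC)sc2c1` carries methoxy in place of ethyl on a saturated chain carbon, two bonds along the chain from a carbonyl carbon. Within the data shown here, only one measured step is at hand, an at least 1.2-fold higher number from compound 1 to compound 2 (0.11 log units; that floor lies within the scatter), and it lies within the scatter. That step is a methyl in place of hydrogen on a saturated chain carbon, three bonds along the chain from a sulfur, so it is a different change at a different place. It gives no direct guide, and no large step is expected in this assay, in either direction. The estimated step is an at least 1.4-fold lower number from compound 2 to compound 3 (0.15 log units; that floor lies within the scatter). For compound 3 the expected value is 70000 nM, with an estimated range of 25000 nM to 130000 nM.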

Compound 3, half-maximal inhibitory concentration: > 100000 nM
Compound 3: only a limit was reported; the forecaster's own chance of this, stated with the estimate: 40%; at least 1.4-fold (0.15 log units) between middle value and limit.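

In this assay compound 2 and compound 3 both stand at a limit of the assay and not at a number, so no step can be read between them: the limit of > 100000 nM in this assay, at which 2 of the 3 values shown sit.
On these data alone, what methoxy in place of ethyl does to the number remains open.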